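This account rests on a few compounds, and the source may have more. Where it says the series, first, only, none or still open, it means among the compounds named here.

Measured so far in a functional assay on MCF7 cells (Homo sapiens) for inhibition, read by MTT assay, with a stated time of 48 h; a higher number here means a weaker inhibitor, a lower number a stronger inhibitor: compound 1 `COc1cc2cc(C(=O)NCc3ccc(F)cc3)c(=O)oc2cc1OCCCOc1no[n+]([O-])c1S(=O)(=O)c1ccccc1` gives 370 nM, and compound 2 `COc1cc2cc(N)c(=O)oc2cc1OCCCOc1no[n+]([O-])c1S(=O)(=O)c1ccccc1` gives 2020 nM.

Going by the values given here, compound 2 stands highest of the two, and the only measured step, a 5.5-fold higher number from compound 1 to compound 2 (0.74 log units; beyond the scatter), runs in that direction. Compound 3 `COc1cc2cc(C(=O)Nc3ccc(F)cc3)c(=O)oc2cc1OCCCOc1no[n+]([O-])c1S(=O)(=O)c1ccccc1` carries the change ((4-fluorophenyl)carbamoyl in place of amino on an aromatic carbon), which largely retraces that step: compound 3 shares with compound 1 a carbamoyl group bearing a fluorinated aromatic ring. The step of a 4.8-fold lower number from compound 2 to compound 3 (0.68 log units; beyond the scatter) is therefore expected to be a lower number, roughly reversing the measured step. Compound 3 is estimated at 420 nM, with a range of 150 nM to 1200 nM.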

Compound 3, half-maximal inhibitory concentration: 860 nM
Compound 3: middle estimate off by 2.0-fold (0.31 log units), on the low side; the range from low to high includes it.
By their numbers in this assay, from the lowest: compound 1; then compound 3; then compound 2.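

In this assay there is a 2.3-fold lower number from compound 2 to compound 3 (0.37 log units; beyond the scatter) on swapping amino for (4-fluorophenyl)carbamoyl, so a second carbamoyl group at this position also gives a lower number than amino. The group on the amide-type nitrogen counts too: there is a 2.3-fold higher number from compound 1 to compound 3 (0.37 log units; beyond the scatter) when 4-fluorophenyl replaces 4-fluorobenzyl, so the two amides are not interchangeable. Nothing measured here gives a reason for either step.

Still open, on these data alone, is whether a longer chain such as 2-phenylethyl on that nitrogen would give a lower number than compound 1, and whether the fluorine matters, which plain benzyl would test.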